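This account rests on a few compounds, and the source may have more. Where it says the series, first, only, none or still open, it means among the compounds named here.

Working notes. Two compounds of the series have numbers in an assay for inhibition of histone deacetylase 4 (Homo sapiens); on this read-out higher numbers stand for weaker inhibition and lower numbers for stronger inhibition. Compound 1 `O=C(c1ccc(-c2nc(-c3ccc(Cl)cc3Cl)no2)s1)C(F)(F)F` gives 240 nM, the higher of the two. Compound 2 `O=C(c1ccc(-c2nc(CS(=O)(=O)c3cccs3)no2)s1)C(F)(F)F` gives 35 nM; the gap between compound 1 and compound 2 lies beyond the scatter, so compound 2 is the stronger inhibitor of the pair. Compound 3 `O=C(c1ccc(-c2nc(-c3cccs3)no2)s1)C(F)(F)F` has not yet been measured. It differs from compound 1 in a single place: thiophen-2-yl in place of 2,4-dichlorophenyl on an aromatic carbon. Among the measured compounds shown here, no measured pair differs in only one place, so there is no direct precedent for the size of this step; compound 2 also contains a thiophene ring, but differs from compound 1 in more than one place, so its value alone cannot fix the effect of the swap. A modest step toward weaker inhibition, or none beyond the scatter, is expected, estimated at a 1.7-fold higher number from compound 1 to compound 3 (0.22 log units; within the scatter). For compound 3 the estimated value is 400 nM, with a range from 100 nM to 1500 nM.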

Compound 3, half-maximal inhibitory concentration: 95 nM
The estimate for compound 3 lay 4.2-fold (0.62 log units) above the measured number, outside the stated range (below it).
By their numbers in this assay, from the lowest: compound 2; then compound 3; then compound 1.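

On this assay the aromatic carbon between two ring nitrogen atoms now has its first single-place step: thiophen-2-yl in place of 2,4-dichlorophenyl gives stronger inhibition (a 2.5-fold lower number from compound 1 to compound 3 (0.40 log units; beyond the scatter)), so the 2,4-dichlorophenyl group is not required here for inhibition in this series. The change replaces a six-membered aromatic ring of carbon only with a five-membered aromatic ring with one hetero atom and removes both chlorine atoms at once, so the step cannot be divided among these differences. Nothing available accounts for the direction or size of the step.

From the compounds shown here alone, the effect of an unsubstituted phenyl or a monochlorophenyl group at this position remains open, which would separate the ring change from the loss of chlorine. Also open, going by these compounds, is how an amine or a carboxylic acid on the thiophen-2-yl ring would shift the number.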